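Methyl to fluoro on the methylsulfanyl aryl imidazoline

A few compounds are considered here, and "the series" means these few. Any claim that something is new, unique, unknown or untested is made for them only; others in the source may bear on it.

Compound 1 `CSc1ccc(C)cc1NCC1=NCCN1` is the reference point of this small set. In a functional assay for agonist activity at Alpha-1B adrenergic receptor (Homo sapiens) (on this read-out lower numbers stand for an effect already at smaller amounts and higher numbers for an effect only at larger amounts of compound), compound 1 gives 0.417 nM, the lowest of the two numbers shown. Going by the values given here, compound 2 `Cc1ccc(S(C)(=O)=O)c(NCC2=NCCN2)c1` gives 141 nM in this assay, and the single measured step, a 340-fold higher number from compound 1 to compound 2 (2.53 log units; beyond the scatter), is a large one. Compound 3 `CS(=O)(=O)c1cc(F)ccc1NCC1=NCCN1` reaches only the limit of < 100000 nM in this assay, at which 1 of the 3 values shown sits, in this assay; compound 3 therefore gives < 100000 nM, which is a limit and not a number.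

Compound 4 `CSc1ccc(F)cc1NCC1=NCCN1` is not yet measured. It differs from compound 1 by fluoro in place of methyl on an aromatic carbon. Among the compounds with values here, no measured step covers this change: compound 2 and compound 3 differ in the same way, but compound 3 shows only a limit, so their pair yields no step size. Within the data shown here, the one measured step concerns the methylsulfanyl-to-methylsulfonyl exchange, which compound 4 keeps as methylsulfanyl. With the retained methylsulfanyl group of compound 1 at 0.417 nM, the step of a 3.6-fold higher number from compound 1 to compound 4 (0.56 log units; beyond the scatter) is expected to be small, in either direction or none beyond the scatter. Compound 4 is estimated at 1.5 nM, with a range from 0.2 nM to 12 nM.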

Compound 4, half-maximal effective concentration: 1.86 nM
Beside the measured number, compound 4's estimate is 1.2-fold (0.09 log units) below it; the range from low to high includes it.
By their numbers in this assay, from the lowest: compound 1; then compound 4; then compound 2.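

At the aromatic carbon para to a methylsulfanyl group, fluoro in place of methyl gives a 4.5-fold higher number from compound 1 to compound 4 (0.65 log units; beyond the scatter) in this assay. Going by these compounds alone, this modest step is the first measured change at this position, and it is much smaller than the large exchange on the sulfur, a 340-fold higher number from compound 1 to compound 2 (2.53 log units; beyond the scatter). With methylsulfanyl retained, compound 4 still gives a low number, so this position accepts either methyl or fluoro without a large step in this pair, and nothing shown gives a cause for that step.

Compound 3 stands at a limit and not a number, so the same change in the methylsulfonyl pair cannot be read: the limit of < 100000 nM in this assay, at which 1 of the 4 values shown sits.

From the compounds shown here alone, whether a methoxy group, an amine or a carboxylic acid at this position would keep the number low remains open.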